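From Chloro to Phenyl: Will Tolerance Shift?

A few compounds are considered here, and "the series" means these few. Any claim that something is new, unique, unknown or untested is made for them only; others in the source may bear on it.

In an ADME assay on L929 cells (Mus musculus) for cytotoxicity, read by resazurin assay, with a stated time of 96 h (a lower number here means that less compound is tolerated, a higher number that more compound is tolerated), compound 3 `NC(=S)N/N=C(\COc1ccc(Cl)cc1)c1ccc(Br)cc1` is reported only as a limit, < 25100 nM. Two close relatives have real numbers: compound 1 `CC(C)c1ccc(OC/C(=N\NC(N)=S)c2ccc(Br)cc2)cc1` gives 24600 nM and compound 2 `COc1ccc(OC/C(=N\NC(N)=S)c2ccc(Br)cc2)cc1` gives 102000 nM. Compound 4 `NC(=S)N/N=C(\COc1ccc(-c2ccccc2)cc1)c1ccc(Br)cc1` has phenyl in place of chloro on an aromatic carbon, para to a large group (phenyl in place of chloro on an aromatic carbon).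

The three measured compounds differ at that same spot, so their steps are the best guide. Methoxy in place of isopropyl gave a 4.1-fold higher number from compound 1 to compound 2 (0.62 log units; beyond the scatter), and chloro in place of methoxy gave an at least 4.0-fold lower number from compound 2 to compound 3 (0.60 log units; beyond the scatter). Chloro in place of isopropyl gave a step that the limit leaves unreadable from compound 1 to compound 3. Only methoxy, in compound 2, stands apart from the other two.

Phenyl, like the isopropyl of compound 1 at 24600 nM, is made of carbon only, so compound 4 is expected to stay low in this assay and not climb towards compound 2. No step beyond the usual scatter is expected, and the estimated step is a step that the limit leaves unreadable from compound 3 to compound 4. For compound 4 the estimate is 20000 nM, with an expected range of 7000 nM to 60000 nM.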

Compound 4, half-maximal cytotoxic concentration: 90800 nM
For compound 4 the middle estimate is 4.5-fold (0.66 log units) below the measured one; the measured number lies above the stated range.
By their numbers in this assay, from the lowest: compound 1; then compounds 4 and 2 (each within the scatter of the next).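

In this assay, containing only carbon does not settle the outcome at this position: the change to phenyl gives a 3.7-fold higher number from compound 1 to compound 4 (0.57 log units; beyond the scatter), while against methoxy it gives a 1.1-fold lower number from compound 2 to compound 4 (0.05 log units; within the scatter), so compound 2 no longer stands alone. Phenyl in place of chloro, which adds a six-membered aromatic ring of carbon only, gives an at least 3.6-fold higher number from compound 3 to compound 4 (0.55 log units; beyond the scatter). The reading for compound 3 is a limit and not a number: the limit of < 25100 nM in this assay, at which 1 of the 4 values shown sits.

As far as these compounds go, what methoxy and phenyl have in common, setting them apart from isopropyl and chloro in this assay, remains open. From the compounds shown here alone, it also remains open whether an amine, a carboxylic acid or a longer chain at this position would fall with the methoxy and phenyl compounds or with the other two.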